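Capping the hydroxy group of compound 3

This account rests on a few compounds, and the source may have more. Where it says the series, first, only, none or still open, it means among the compounds named here.

Compound 1 `COc1ccc(OCc2ccc3ccccc3n2)cc1C1(c2ccccc2)CC2CCC1C2` gives 1100 nM
Compound 2 `c1ccc(COc2ccc(OCc3ccc4ccccc4n3)cc2C2(c3ccccc3)CC3CCC2C3)cc1` gives > 3000 nM (a limit of the assay)
Compound 3 `Oc1ccc(OCc2ccc3ccccc3n2)cc1C1(c2ccccc2)CCCC1` gives 1920 nM

In a functional assay on blood (Homo sapiens) for inhibition (on this read-out higher numbers stand for weaker inhibition and lower numbers for stronger inhibition), compound 3 gives 1920 nM and so lies within the usual scatter of compound 1 (1100 nM). Compound 4 `O=C(Nc1cccnc1)Oc1ccc(OCc2ccc3ccccc3n2)cc1C1(c2ccccc2)CCCC1` is not yet measured. It differs from compound 3 by (pyridin-3-yl)carbamoyl in place of hydrogen on an oxygen on an aromatic ring in one place: (pyridin-3-yl)carbamoyl in place of hydrogen on an oxygen on an aromatic ring.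

Among the measured compounds shown here, only one measured step enlarges the group on such an oxygen. That step is an at least 2.7-fold higher number from compound 1 to compound 2 (0.43 log units; beyond the scatter) and it points toward weaker inhibition. It involves a different core and a different entering group, so it is only a loose guide. A small move toward a higher number in this assay is therefore expected, perhaps none beyond the scatter. The expected change is a 1.5-fold higher number from compound 3 to compound 4 (0.16 log units; within the scatter) on this estimate. For compound 4 the estimated value is 2800 nM with an expected range from 900 nM to 9000 nM and a real chance of the expected result being only a limit of the assay.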

Compound 4, half-maximal inhibitory concentration: 52 nM
Estimate against measurement, compound 4: 54-fold (1.73 log units) above; measured number below the stated range.
By their numbers in this assay, from the lowest: compound 4; then compounds 1 and 3 (each within the scatter of the next). At a limit, above all of these: compound 2.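

In this assay placing (pyridin-3-yl)carbamoyl on the oxygen on the aromatic ring gives a 37-fold lower number from compound 3 to compound 4 (1.57 log units; beyond the scatter) and so moves toward stronger inhibition, which shows that this oxygen need not remain a free hydroxy group and that a large entering group can bring a large gain here. The only earlier enlargement on such an oxygen was an at least 2.7-fold higher number from compound 1 to compound 2 (0.43 log units; beyond the scatter) and ran the other way on a different core, so across these compounds the size of the entering group alone does not decide the outcome. The value of compound 2 in that step is a limit of the assay.

Still open, as far as these compounds go, is whether the gain needs the pyridine ring, the carbamoyl link or both, which a phenylcarbamoyl or an acetyl group on the same oxygen could separate. Nothing shown gives a reason for the gain.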